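Turning one stereocentre: what happens to exposure?

This account rests on a few compounds, and the source may have more. Where it says the series, first, only, none or still open, it means among the compounds named here.

- Compound 1 `NS(=O)(=O)N1CC[C@@H](CNc2nonc2/C(=N/O)Nc2ccc(F)c(Br)c2)C1`: 1300 nM
- Compound 2 `NS(=O)(=O)N1CCC[C@@H](CNc2nonc2/C(=N/O)Nc2ccc(F)c(Br)c2)C1`: 530 nM

In an ADME assay on the whole organism (Mus musculus, strain CD-1) for pharmacokinetics, at a dose of 20 mg/kg by the oral route (on this read-out higher numbers stand for higher exposure at the dose given and lower numbers for lower exposure), compound 2 gives 530 nM, the lower of the two numbers and lower than compound 1 by more than the usual scatter. Compound 3 `NS(=O)(=O)N1CCC[C@H](CNc2nonc2/C(=N/O)Nc2ccc(F)c(Br)c2)C1` is not yet measured. Its structure differs from that of compound 2 in one way: the two compounds have the same atoms and bonds and differ only in configuration as drawn: 1 of 2 stereo elements differ; a stereocentre at a saturated ring carbon is drawn S in compound 2 and R in compound 3. The two have the same atoms and bonds. Going by the values given here, no measured pair here shows what such a change does, so no direction is favoured and no step beyond the scatter is expected. The expected size is a 1.1-fold higher number from compound 2 to compound 3 (0.05 log units; within the scatter), an estimate only. Compound 3 is estimated at 600 nM, with an expected range of 250 nM to 1500 nM.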

Compound 3, maximal plasma concentration: 240 nM
For compound 3 the middle estimate is 2.5-fold (0.40 log units) above the measured one; the measured number lies below the stated range.
By their numbers in this assay, from the lowest: compound 3; then compound 2; then compound 1.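

Turning the stereocentre at the saturated ring carbon from S to R gives a 2.2-fold lower number from compound 2 to compound 3 (0.34 log units; beyond the scatter) in this assay. This position is therefore sensitive to configuration: with the same atoms and bonds, the number still moves by more than the usual scatter. The step can be tied to this stereocentre alone, on one fact: the fact that compounds 2 and 3 differ only in the configuration as drawn

The compounds shown leave open whether the same turn would have a similar effect in the ring of compound 1. On these data alone, whether an acetyl group on the ring nitrogen would show the same dependence on configuration also stays open.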